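The compounds below may be only part of what the source reports. "The series", "measured", "known", "first", "only" and "open" are said of these compounds alone.

For the measured compounds named here, in a functional assay on HeLa cells (Homo sapiens) for cytotoxicity, read by MTT assay, with a stated time of 72 h (a higher number here means a weaker inhibitor, a lower number a stronger inhibitor), compound 2 `NCc1nnc(-c2cc(S(N)(=O)=O)c(SCc3ccccc3)cc2Cl)o1` gives 490000 nM, the highest of the two numbers known here; the nearest is compound 1 `Cc1ccc(C)c(N2CCN(Cc3nnc(-c4cc(S(N)(=O)=O)c(SCc5ccccc5)cc4Cl)o3)CC2)c1`, which in this assay gives 16000 nM, a gap well beyond the scatter. Compound 3 `NS(=O)(=O)c1cc(-c2nnc(/C=C/c3ccc(Cl)cc3)o2)c(Cl)cc1SCc1ccccc1` has not yet been measured. It differs from compound 2 by 2-(4-chlorophenyl)ethenyl in place of aminomethyl on an aromatic carbon. Since compound 1, which also bears a large group, reaches 16000 nM, a downward step is expected, a 16-fold lower number from compound 2 to compound 3 (1.21 log units; beyond the scatter), well beyond the scatter. Compound 3 is accordingly estimated at 30000 nM, with a range from 5000 nM to 200000 nM.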

Compound 3, half-maximal inhibitory concentration: 40000 nM
Estimate against measurement, compound 3: 1.3-fold (0.12 log units) below; low and high end bracket the measured number.
By their numbers in this assay, from the lowest: compound 1; then compound 3; then compound 2.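

In this assay, replacing aminomethyl with 2-(4-chlorophenyl)ethenyl on this aromatic carbon gives a 12-fold lower number from compound 2 to compound 3 (1.09 log units; beyond the scatter). The entering group holds no nitrogen and no hydrogen-bond donor or acceptor, so a lower number at this position does not depend on a nitrogen in the group placed there. No measured evidence here explains the step.

The compounds shown leave open whether the double bond or the chlorine accounts for the step. A saturated 2-(4-chlorophenyl)ethyl chain or an unsubstituted 2-phenylethenyl group at this position would separate the two.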